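The source may report more compounds than this note shows. Statements on the series, on what has been measured and on what is new or still open speak of the compounds shown alone.

Measured so far in a functional assay on NCI-H23 cells (Homo sapiens) for cytotoxicity, read by sulforhodamine B assay, with a stated time of 72 h; on this read-out higher numbers stand for weaker inhibition of growth and lower numbers for stronger inhibition of growth:

Compound 1, `O=C(Nc1ccc(C(F)(F)F)cc1)C1CCc2ccccc2N1`: compound 1 gives 25800 nM.
Compound 2, `O=C(Nc1cc(C(F)(F)F)cc(C(F)(F)F)c1)C1CCc2ccccc2N1C(=O)c1ccc(Cl)cc1`: compound 2 gives 889 nM.
Compound 3, `O=C(Nc1cc(C(F)(F)F)cc(C(F)(F)F)c1)c1ccc2ccccc2n1`: compound 3 gives 1440 nM.

Compound 2 has the lowest number of the three in this assay; compound 3 sits within the scatter of it, while compound 1 lies well beyond the scatter on the weaker side. Compound 4, `O=C(Nc1cc(C(F)(F)F)cc(C(F)(F)F)c1)C1CCc2ccccc2N1`, is not yet measured. It differs from compound 2 by hydrogen in place of (4-chlorophenyl)carbonyl on a nitrogen on an aromatic ring in a ring. Within the data shown here, no measured pair shows this step directly. Compound 1, which likewise carries hydrogen on that ring nitrogen, gives 25800 nM, so compound 4 is expected to fall clearly weaker than compound 2, by an estimated step of an 11-fold higher number from compound 2 to compound 4 (1.05 log units; beyond the scatter) beyond the scatter. For compound 4 the estimated value in this assay is 10000 nM, with a range from 3000 nM to 35000 nM.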

Compound 4, concentration for 50% growth inhibition: 8410 nM
Compound 4: the middle estimate sits 1.2-fold (0.08 log units) above what was measured; the range from low to high includes it.
By their numbers in this assay, from the lowest: compounds 2 and 3 (each within the scatter of the next); then compound 4; then compound 1.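

In this assay, among these compounds, hydrogen in place of (4-chlorophenyl)carbonyl on the ring nitrogen gives a 9.5-fold higher number from compound 2 to compound 4 (0.98 log units; beyond the scatter) and so weakens growth inhibition, the first step that changes one place only. At this position of the shared core, the (4-chlorophenyl)carbonyl group therefore goes with stronger inhibition of growth, beyond the scatter. No measurement bears on the reason for this step.

From the compounds shown here alone, whether the carbonyl or the 4-chlorophenyl ring carries the difference stays open. An acetyl or a benzyl group on this nitrogen would separate the two.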